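Allyl in place of methyl on the amino group

The compounds below may be only part of what the source reports. "The series", "measured", "known", "first", "only" and "open" are said of these compounds alone.

Compound 1 `CNc1nc(SC)nc2ncccc12` carries a methylamino group on the shared core. Within the data shown here, in a functional assay (Nicotiana tabacum) (a lower number here means a stronger inhibitor, a higher number a weaker inhibitor), compound 1 gives 2920 nM, the second highest of the three numbers measured so far. Compound 2 `CCCCNc1nc(SC)nc2ncccc12` gives 270 nM and compound 3 `CCCCC(CC)CNc1nc(SC)nc2ncccc12` gives 15900 nM.

Compound 4 `C=CCNc1nc(SC)nc2ncccc12` differs from compound 1 by vinyl in place of hydrogen on a saturated chain carbon bound to a nitrogen on an aromatic ring. Among the measured compounds shown here, two measured steps bear on this. Lengthening the chain from methyl to butyl gave an 11-fold lower number from compound 1 to compound 2 (1.03 log units; beyond the scatter), while the much larger 1-ethylpentyl branch gave a 5.4-fold higher number from compound 1 to compound 3 (0.74 log units; beyond the scatter). Allyl lies in length between methyl and butyl and, like butyl, is unbranched, so a lowering of the number is expected for compound 4, though probably smaller than the step to compound 2. The estimated step is a 3.7-fold lower number from compound 1 to compound 4 (0.56 log units; beyond the scatter). Compound 4 is therefore expected to give about 800 nM in this assay, with a range from 250 nM to 2600 nM.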

Compound 4, half-maximal inhibitory concentration: 400 nM
Estimate against measurement, compound 4: 2.0-fold (0.30 log units) above, within the range that was stated.
By their numbers in this assay, from the lowest: compounds 2 and 4 (each within the scatter of the next); then compound 1; then compound 3.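

In this assay, replacing methylamino with allylamino lowers the number (a 7.3-fold lower number from compound 1 to compound 4 (0.86 log units; beyond the scatter)), and compound 4 cannot be told apart from the butylamino compound (a 1.5-fold higher number from compound 2 to compound 4 (0.17 log units; within the scatter)), so among these compounds the lowering does not need a chain as long as butyl. Among these compounds, the large step from the branched side chain (a 40-fold lower number from compound 3 to compound 4 (1.60 log units; beyond the scatter)) shows how much the outcome at this position depends on which group sits there, with compound 3 the one compound whose number lies above that of compound 1. Nothing measured here explains these differences.

From the compounds shown here alone, whether the double bond of allyl matters remains open, and propylamino, its saturated counterpart, would test that. Also open, going by these compounds, is how a longer unbranched chain such as hexyl compares, which would help separate the effect of chain length from that of branching.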